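Swapping the benzyl group on a triazole-linked anilide

The source may report more compounds than this note shows. Statements on the series, on what has been measured and on what is new or still open speak of the compounds shown alone.

Going by the values given here, compound 3 `O=C(NCc1cn(Cc2ccc(Cl)cc2)nn1)c1cn(-c2ccccc2)nc1-c1ccc(F)cc1` gives 130 nM in a functional assay on MCF7 cells (Homo sapiens) for antiproliferative activity, read by sulforhodamine B assay, with a stated time of 48 h (on this read-out higher numbers stand for weaker inhibition of growth and lower numbers for stronger inhibition of growth), and it holds the only number among the three values shown. Compound 1 `O=C(NCc1cn(Cc2ccc(Cl)cc2)nn1)c1cn(-c2ccccc2)nc1-c1ccccc1` sits at > 100000 nM, a limit rather than a number. Compound 2 `COc1ccc(Cn2cc(CNC(=O)c3cn(-c4ccccc4)nc3-c3ccccc3)nn2)cc1` likewise sits at > 100000 nM, also a limit. The step of an at least 760-fold lower number from compound 1 to compound 3 (2.88 log units; beyond the scatter) is large and clearly beyond the scatter. The step that the two limits leave unreadable from compound 1 to compound 2 cannot be read because of the limit of > 100000 nM in this assay, at which 2 of the 3 values shown sit.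

Compound 4 `COc1ccc(Cn2cc(CNC(=O)c3cn(-c4ccccc4)nc3-c3ccc(F)cc3)nn2)cc1OC` differs from compound 3 by 3,4-dimethoxyphenyl in place of 4-chlorophenyl on a saturated chain carbon bound to an aromatic nitrogen. Among the compounds with values here, the only measured step that resembles this change, methoxy in place of chloro, is the one from compound 1 to compound 2, and it is unreadable. No readable step bears on it, so the direction of the step is open and the expectation leans on compound 3 alone. Compound 4 is therefore expected to lie near 500 nM, within 100 nM to 10000 nM, which would mean an estimated step of a 3.8-fold higher number from compound 3 to compound 4 (0.59 log units; beyond the scatter).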

Compound 4, concentration for 50% growth inhibition: > 100000 nM
Compound 4 gave a limit, no number; the forecaster's own chance of this, stated with the estimate: 20%; middle value at least 200-fold (2.30 log units) away from the limit.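

Exchanging 4-chlorobenzyl for 3,4-dimethoxybenzyl on a saturated chain carbon bound to an aromatic nitrogen gives, in this assay, an at least 760-fold higher number from compound 3 to compound 4 (2.88 log units; beyond the scatter). Going by these compounds alone, this is the first readable step at this position, since the earlier change of methoxy in place of chloro cannot be read, and it shows that with the fluoro group present, the result depends strongly on the group held here. Compound 4 gives a limit, not a number, so the true size of the loss stays unknown: the limit of > 100000 nM in this assay, at which 3 of the 4 values shown sit.

The compounds shown do not tell whether one methoxy group or two accounts for the loss, as 4-methoxybenzyl appears only without the fluoro group. Going by these compounds, it also remains open how an amine, a carboxylic acid or a longer chain on the benzyl ring would fare at this position.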